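A few compounds are considered here, and "the series" means these few. Any claim that something is new, unique, unknown or untested is made for them only; others in the source may bear on it.

Working notes on the series.

In a functional assay on HeLa cells (Homo sapiens) for inhibition, read by sulforhodamine B assay (a higher number here means a weaker inhibitor, a lower number a stronger inhibitor), compound 1 `O=C1C=C(Nc2ccc(I)cc2)C(=O)c2c1nc1n2[C@H]2OC[C@@H](O)[C@H]2OC1` gives 4070 nM. Compound 2 `O=C1C=C(Nc2ccccc2)C(=O)c2c1nc1n2[C@H]2OC[C@@H](O)[C@H]2OC1` gives 5620 nM in this assay, and the step of a 1.4-fold higher number from compound 1 to compound 2 (0.14 log units; within the scatter) shows that hydrogen in place of iodo on an aromatic carbon changes little. Compound 3 `O=C1C=C(NC2CCCCC2)C(=O)c2c1nc1n2[C@H]2OC[C@@H](O)[C@H]2OC1` is different: in this assay compound 3 reaches only a limit, > 16000 nM, so no number is known for it. Compound 3 therefore stands at the weak end of what has been measured, at the limit (the limit of > 16000 nM in this assay, at which 1 of the 3 values shown sits). The steps of an at least 3.9-fold higher number from compound 1 to compound 3 (0.59 log units; beyond the scatter) and an at least 2.8-fold higher number from compound 2 to compound 3 (0.45 log units; beyond the scatter) both show that cyclohexyl in place of an aryl group on the amine nitrogen costs potency in this assay.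

Compound 4 `CCCN(CCC)C1=CC(=O)c2nc3n(c2C1=O)[C@H]1OC[C@@H](O)[C@H]1OC3` has not yet been measured in this assay. It differs from compound 3 as follows: dipropylamino in place of cyclohexylamino on a double-bonded ring carbon. The measured steps that bear on it are those into compound 3, both of which led to the limit. Compound 4 keeps a non-aromatic amine and drops the hydrogen-bond donor, so no recovery towards compound 1 or compound 2 is expected; the expected step that the limit leaves unreadable from compound 3 to compound 4 is none beyond the scatter, with a limit value again likely. Compound 4 is estimated at 25000 nM in this assay, within 10000 nM to 80000 nM.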

Compound 4, half-maximal inhibitory concentration: > 16000 nM
Compound 4 ended at the assay's limit; the forecaster's own chance of this, stated with the estimate: 70%; the middle value does not contradict the limit.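

In this assay, dipropylamino in place of anilino gives an at least 2.8-fold higher number from compound 2 to compound 4 (0.45 log units; beyond the scatter), and dipropylamino in place of (4-iodophenyl)amino gives an at least 3.9-fold higher number from compound 1 to compound 4 (0.59 log units; beyond the scatter), so the loss at this double-bonded ring carbon is not confined to cyclohexylamino: an open-chain substituent with no ring and no hydrogen-bond donor on its nitrogen also falls short of both aryl amines. Both compounds without an aryl group on this nitrogen, compound 3 and compound 4, rest on a limit of the assay and not on a number: the limit of > 16000 nM in this assay, at which 2 of the 4 values shown sit.

The steps between compounds at this limit cannot be read, so the series gives no order between cyclohexylamino and dipropylamino and does not show whether removing the hydrogen on the nitrogen matters once the aryl group is gone.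

Still open, going by these compounds, is whether the aryl ring or the hydrogen on the nitrogen carries the activity: N-methylanilino would keep the ring without that hydrogen, while propylamino would keep the hydrogen without any ring. Also open, on these data alone, is how benzylamino, with a carbon spacer before the phenyl ring, or a methoxy group or carboxylic acid on that ring, would read in this assay.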